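The source may report more compounds than this note shows. Statements on the series, on what has been measured and on what is new or still open speak of the compounds shown alone.

Compound 1, `COc1ccc(-c2cn(-c3ccc(OC)c(OC)c3)nn2)cc1O`, is the reference point in a functional assay on MDA-MB-231 cells (Homo sapiens) for cytotoxicity, read by MTT assay; a lower number here means a stronger inhibitor, a higher number a weaker inhibitor. In this assay compound 1 gives > 100 nM, which is a limit of the assay and not a number, so where compound 1 truly stands is known only as a bound (the limit of > 100 nM in this assay, at which 1 of the 3 values shown sits). Two measured neighbours differ from compound 1 in one place each. Compound 2, `COc1ccc(-c2cn(-c3ccc(OC)c(O)c3)nn2)cc1O`, has hydrogen in place of methyl on an oxygen on an aromatic ring; in this assay compound 2 gives > 10000 nM, again a limit of the assay. Compound 3, `COc1ccc(-c2cn(-c3ccc(OC)c(OC)c3)nn2)cc1`, has hydrogen in place of hydroxy on an aromatic carbon; in this assay compound 3 gives > 10000 nM, also a limit. The steps a step that the two limits leave unreadable from compound 1 to compound 2 and a step that the two limits leave unreadable from compound 1 to compound 3 therefore cannot be sized, because both readings rest on (the limit of > 10000 nM in this assay, at which 2 of the 3 values shown sit).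

The unmeasured compound 4, `COc1ccc(-c2cn(-c3cc(OC)c(OC)c(OC)c3)nn2)cc1O`, differs from compound 1 by methoxy in place of hydrogen on an aromatic carbon. Neither measured step concerns an added methoxy, and neither could be sized, so no direction beyond the scatter can be expected from them. Compound 4 is therefore expected to give about 3000 nM in this assay, between 200 nM and 30000 nM, quite possibly again as a limit. The estimated step is a step that the limit leaves unreadable from compound 1 to compound 4.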

Compound 4, half-maximal inhibitory concentration: > 10000 nM
Compound 4: no number, only a limit (the forecaster's own chance of this, stated with the estimate: 70%); middle value at least 3.3-fold (0.52 log units) away from the limit.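

In this assay compound 4 gives > 10000 nM as a limit of the assay and not a number. Compound 1 also stands only as a limit, so the step between compound 1 and compound 4 cannot be read. The compounds shown leave open where any of the four truly stands and whether the added methoxy changes that at all.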